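Chloro in Place of Bromo on the Aryl Sulfonamide

The compounds below may be only part of what the source reports. "The series", "measured", "known", "first", "only" and "open" are said of these compounds alone.

Of the compounds shown here, three that share one core have been measured in a functional assay on HL-60 cells (Homo sapiens) for antiproliferative activity, read by MTT assay, tested at 100 ug/mL; a higher number here means more inhibition at the concentration tested (going by the name of the read-out), a lower number less inhibition. Compound 1 `COc1cc(OC)nc(NS(=O)(=O)C2CCCCC2=O)n1` gives 2.62% in this assay. Compound 2 `Cc1cc(F)ccc1NS(=O)(=O)C1CCCCC1=O` gives -0.99%. Compound 3 `O=C1CCCCC1S(=O)(=O)Nc1ccccc1Br` gives 15.4%, the highest of the three numbers; its nearest neighbour is compound 1, and the gap down to that compound lies beyond the scatter, as does the wider gap down to compound 2.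

Compound 4 `O=C1CCCCC1S(=O)(=O)Nc1ccccc1Cl` has not yet been measured. It differs from compound 3 in a single place: chloro in place of bromo on an aromatic carbon. Among the measured compounds shown here, no measured pair in this set shows what exchanging one halogen for another does here, so the size of such a step cannot be read from the data. Given that compound 3 already sits only modestly above the others, the account expects a small step from compound 3 to compound 4, a number 4.4 percentage points lower from compound 3 to compound 4 (within the scatter), most likely within the scatter and, if anything, pointing downward. Compound 4 is accordingly estimated at 11% in this assay, with a range from 0% to 24%.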

Compound 4, a percentage reported as inhibition, at one concentration (the size of the read-out at that concentration, not a potency): 0.29%
For compound 4 the middle estimate is 10.7 percentage points above the measured one; the measured number falls inside the stated range.
By their numbers in this assay, from the lowest: compounds 2, 4 and 1 (each within the scatter of the next); then compound 3.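

In this assay, among the compounds shown here, the exchange of bromo for chloro on an aromatic carbon, ortho to a large group, gives the first step in this set between compounds that differ in one place: a number 15.1 percentage points lower from compound 3 to compound 4 (beyond the scatter). The step lies beyond the usual scatter, so the choice of halogen at this position matters in this assay, and the number seen for compound 3 is not carried by the rest of the structure alone. Nothing available explains why these two halogens part in this way.

The compounds shown leave open whether the number at this position follows the halogen series, and whether iodo, fluoro or a plain hydrogen there, or a non-halogen group such as methyl or methoxy, would stand nearer to compound 3 or to compound 4. They also leave open whether bromo on another carbon of the same ring would keep the number of compound 3, and how either halogen compound would behave across a range of concentrations rather than at a single one.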